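Compound 3: a swapped amine side chain, activity still unknown

The source may report more compounds than this note shows. Statements on the series, on what has been measured and on what is new or still open speak of the compounds shown alone.

Measured in a functional assay on Bel-7402 cells (Homo sapiens) for antiproliferative activity, read by MTT assay, with a stated time of 72 h; a higher number here means a weaker inhibitor, a lower number a stronger inhibitor
compound 1 (`COc1ccc(Cn2c(C(=O)O)c(CNCc3cccc(OC)c3)c3ccccc32)cc1`) gives 52900 nM
compound 2 (`COc1ccc(Cn2c(C(=O)O)c(CN(C)Cc3cccc(OC)c3)c3ccc(C)cc32)cc1`) gives 33000 nM

The values of compound 1 and compound 2 lie within the usual scatter of each other, so compound 2 cannot be separated from compound 1 on these numbers. Compound 3 (`COc1ccc(Cn2c(C(=O)O)c(CNCc3ccc(O)c(OC)c3)c3ccc(C)cc32)cc1`) has not yet been measured. It carries (4-hydroxy-3-methoxybenzyl)amino in place of (3-methoxybenzyl)(methyl)amino on a saturated chain carbon bound to an aromatic carbon. Going by the values given here, no measured pair isolates a change at one place, so the data give no size for this one. Among the compounds with values here, with compound 1 at 52900 nM and compound 2 at 33000 nM as the only guide, no shift beyond the scatter is expected in this assay, in either direction. The expected change is small (a 1.1-fold higher number from compound 2 to compound 3 (0.03 log units; within the scatter)). For compound 3 the estimated value is 35000 nM (expected range 13000 nM to 90000 nM).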

Compound 3, half-maximal inhibitory concentration: 13300 nM
For compound 3 the middle estimate is 2.6-fold (0.42 log units) above the measured one; the measured number falls inside the stated range.
By their numbers in this assay, from the lowest: compound 3; then compounds 2 and 1 (each within the scatter of the next).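

In this assay the amine side chain on a saturated chain carbon bound to an aromatic carbon does move the read-out: (4-hydroxy-3-methoxybenzyl)amino in place of (3-methoxybenzyl)(methyl)amino gives a 2.5-fold lower number from compound 2 to compound 3 (0.39 log units; beyond the scatter) and this modest step is the only one here read at a single place. Compound 1 and compound 2 could not show this, as they differ in more than one place and their values lie within the scatter of each other. Nothing measured here accounts for the step.

The swap removes the methyl on the amine and adds the hydroxy group together, so the compounds leave open which of the two changes carries the step. They also leave open how an amide in place of the amine, or an ethyl on the amine, would read.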